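A few compounds are considered here, and "the series" means these few. Any claim that something is new, unique, unknown or untested is made for them only; others in the source may bear on it.

Measured compounds in an assay on CHO cells for displacement of a labelled ligand from histamine receptor H3 (Macaca mulatta), read by scintillation counting, with a stated time of 1 h; on this read-out lower numbers stand for stronger inhibition and higher numbers for weaker inhibition:
Compound 1 `Cc1c(Cl)cc(NC(=O)Nc2ccc(OCCCN3CCCCC3)cc2)cc1Cl`: 18.2 nM
Compound 2 `CC1CCCN1C1CCN(c2ccc(NC(=O)NC3CCCCC3)cc2)C1`: 4.1 nM
Compound 3 `Cc1cc(NC(=O)NC2CCCCC2)ccc1N1CCC(N2CCCC2C)C1`: 11.2 nM

Compound 3 gives the second highest of the three numbers in this assay. Its nearest neighbour is compound 1, whose value lies within the scatter of it; compound 2 sits further away, and the step of a 2.7-fold higher number from compound 2 to compound 3 (0.44 log units; beyond the scatter) is beyond the scatter.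

Compound 4 `CC(=O)N1CCN(C(=O)Nc2ccc(N3CCC(N4CCCC4C)C3)c(C)c2)CC1` differs from compound 3 by 4-acetylpiperazin-1-yl in place of cyclohexylamino on a carbonyl carbon. Going by the values given here, no measured step touches this part of the molecule: the only step in hand exchanges a methyl for hydrogen on an aromatic carbon, so there is nothing to lean on for direction or size. Compound 4 is therefore expected to stay near compound 3, with a 1.3-fold higher number from compound 3 to compound 4 (0.13 log units; within the scatter) as the guess and wide uncertainty, at 15 nM (range 4 nM to 50 nM).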

Compound 4, inhibition constant: 23 nM
The estimate for compound 4 lay 1.5-fold (0.19 log units) below the measured number, within the range that was stated.
By their numbers in this assay, from the lowest: compound 2; then compounds 3, 1 and 4 (each within the scatter of the next, the first and the last beyond it).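

In this assay, the group on this carbonyl carbon can be exchanged at a modest cost: 4-acetylpiperazin-1-yl in place of cyclohexylamino gives a 2.1-fold higher number from compound 3 to compound 4 (0.31 log units; beyond the scatter), and compound 4 still reads 23 nM in the nanomolar range. The exchange removes a hydrogen-bond donor and adds an acceptor, yet the change stays modest. No measured evidence accounts for this shift.

Left open is how much of the step belongs to the acetyl group and how much to the ring. Piperidin-1-yl or unsubstituted piperazin-1-yl on this carbonyl carbon would bear on that question.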